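The source may hold more compounds than are shown below. What is called first, only, known or untested is meant among the compounds shown, and "the series" means these compounds.

Two compounds built on a shared core with two 4-methoxyphenyl groups have been measured so far in a functional assay (aorta) with Rattus norvegicus as the target; on this read-out lower numbers stand for an effect already at smaller amounts and higher numbers for an effect only at larger amounts of compound. Compound 1 `COc1ccc(-c2nc(/N=C(\N)N(C)C)sc2-c2ccc(OC)cc2)cc1` gives 4.8 uM, and compound 2 `COc1ccc(-c2nc(/N=C(\N)[N+]3(C)CCCCC3)sc2-c2ccc(OC)cc2)cc1` gives 21 uM, the higher of the two numbers. Compound 3 `COc1ccc(-c2nc(CN(C)C)sc2-c2ccc(OC)cc2)cc1` differs from compound 2 as follows: a group of 4 heavy atoms (3 carbon, 1 nitrogen; no ring) in place of a group of 10 heavy atoms (7 carbon, 3 nitrogen; one six-membered non-aromatic ring with 1 hetero atom), on an aromatic carbon. The entering group is (dimethylamino)methyl, which has no net charge, whereas the leaving group has a net charge of +1.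

Within the data shown here, only one measured step bears on this change, a 4.4-fold higher number from compound 1 to compound 2 (0.64 log units; beyond the scatter). In that step, the group with no ring gave the lower number, and adding the six-membered ring went with a modest rise. Among the measured compounds shown here, it is only a partial guide, since no measured compound carries (dimethylamino)methyl and the whole group changes here. A modest step towards a lower number is therefore expected in this assay, no larger than the measured one. The expected step is a 2.3-fold lower number from compound 2 to compound 3 (0.37 log units; beyond the scatter). For compound 3, the estimate is 9 uM, with an expected range from 2.5 uM to 30 uM.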

Compound 3, concentration for half-maximal effect: 8.4 uM
Beside the measured number, compound 3's estimate is 1.1-fold (0.03 log units) above it; measured number inside the range.
By their numbers in this assay, from the lowest: compounds 1 and 3 (each within the scatter of the next); then compound 2.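

In this assay, the step of a 2.5-fold lower number from compound 2 to compound 3 (0.40 log units; beyond the scatter) shows that this aromatic carbon does not need the large group of compound 2: (dimethylamino)methyl, with no ring and no net charge, gives a lower number than that group with its six-membered ring and net charge of +1. The step of a 1.8-fold higher number from compound 1 to compound 3 (0.24 log units; within the scatter) lies within the scatter, so compound 1 and compound 3 cannot be told apart, even though their groups differ in size and in the number of nitrogen atoms. Why the numbers fall this way cannot be said, as no separate measurement here speaks to the cause.

Compound 2 and compound 3 differ in ring, charge and size all at once, so these compounds cannot show which of those changes goes with the lower number. A piperidin-1-ylmethyl group at the same carbon would keep the ring without the net charge and help separate these factors, while a longer chain such as 2-(dimethylamino)ethyl or a carboxylic acid would test how much else this position allows.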